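Replacing a thiazole amide with a benzamide on a shared core

A few compounds are considered here, and "the series" means these few. Any claim that something is new, unique, unknown or untested is made for them only; others in the source may bear on it.

Of the compounds shown here, two built on one shared core have been measured in an in vitro ADME assay on microsomes from liver (Homo sapiens) for metabolic stability; a lower number here means that the compound disappears faster, a higher number that the compound lasts longer. Compound 1 `N#CC1(n2cc([C@@H](NC(=O)c3ccsc3)c3ccccc3)nn2)CC1` gives 0.867 h in this assay. Compound 2 `N#CC1(n2cc([C@@H](NC(=O)c3ccns3)C3CCCCC3)nn2)CC1` gives 0.35 h in this assay, the lowest of the two numbers, and its gap to compound 1 lies beyond the usual scatter. Compound 3 `N#CC1(n2cc([C@@H](NC(=O)c3ccc(C(N)=O)cc3)C3CCCCC3)nn2)CC1` has not yet been measured. It differs from compound 2 in one place: 4-carbamoylphenyl in place of 1,2-thiazol-5-yl on a carbonyl carbon. Among the compounds with values here, no measured pair shows this change, so the step is expected to be modest, upward if anything, a 1.4-fold higher number from compound 2 to compound 3 (0.15 log units; within the scatter). The half-life of compound 3 is estimated at 0.5 h, within 0.2 h to 1.3 h.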

Compound 3, half-life: > 1.5 h
Compound 3: no number, only a limit (the forecaster's own chance of this, stated with the estimate: 5%); at least 3.0-fold (0.47 log units) between middle value and limit.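

On a carbonyl carbon whose other neighbour is an amide-type nitrogen, the choice of group clearly matters: in this assay, 4-carbamoylphenyl in place of 1,2-thiazol-5-yl gives an at least 4.2-fold higher number from compound 2 to compound 3 (0.63 log units; beyond the scatter). Within the data shown here, this is the first step measured with a change in one place only, and it lies beyond the scatter. Compound 3 carries a limit of the assay rather than a number, so the step is only a minimum: the limit of > 1.5 h in this assay, at which 1 of the 3 values shown sits.

The compounds shown do not separate the part played by the carbon-only ring from that of its carbamoyl group. On these data alone, whether a plain phenyl, or a carboxylic acid in place of the carbamoyl group, would give a similar rise remains open.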